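Adding a Second Chloro to the Core of Compound 1

The compounds below may be only part of what the source reports. "The series", "measured", "known", "first", "only" and "open" are said of these compounds alone.

Compound 1 `ClCc1ccc(Cn2cnc3c(Cl)ncnc32)cc1` gives 3980 nM in a functional assay on 786-0 cells (Homo sapiens) for cytotoxicity, read by sulforhodamine B assay, with a stated time of 48 h (a lower number here means a stronger inhibitor of growth, a higher number a weaker inhibitor of growth), the lowest of the three numbers shown. Compound 3 `ClCc1ccccc1Cn1cnc2nc(Cl)nc(Cl)c21` gives 7070 nM, which lies within the scatter of compound 1, so the two cannot be ranked. Compound 2 `ClCc1cccc(Cn2cnc3c(Cl)nc(Cl)nc32)c1` gives 26900 nM, a gap beyond the scatter. Compound 4 `ClCc1ccc(Cn2cnc3c(Cl)nc(Cl)nc32)cc1` has not been measured. It differs from compound 1 by chloro in place of hydrogen on an aromatic carbon, placed between two ring nitrogen atoms of the shared core. For the measured compounds named here, no measured pair isolates this single change, so the direction is uncertain. Compound 4 is expected to land with a step of a 1.5-fold higher number from compound 1 to compound 4 (0.18 log units; within the scatter) from compound 1, a small move toward a higher number and within the scatter. The estimate for compound 4 is 6000 nM, between 2000 nM and 18000 nM.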

Compound 4, concentration for total growth inhibition: 29500 nM
For compound 4 the middle estimate is 4.9-fold (0.69 log units) below the measured one; the measured number lies above the stated range.
By their numbers in this assay, from the lowest: compounds 1 and 3 (each within the scatter of the next); then compounds 2 and 4 (each within the scatter of the next).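

In this assay, putting chloro in place of hydrogen on an aromatic carbon between two ring nitrogen atoms gives a 7.4-fold higher number from compound 1 to compound 4 (0.87 log units; beyond the scatter). For the compounds shown here, this is the first pair here that isolates one change, and it shows that this position is sensitive: the added chloro goes with weaker growth inhibition. Nothing available explains the loss.

From the compounds shown here alone, an amine or a methoxy group at this position remains open, as does whether removing this chloro from compound 2 would give a step of similar size.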